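Dithiocarbamate variations at the thiocarbonyl nitrogen

This account rests on a few compounds, and the source may have more. Where it says the series, first, only, none or still open, it means among the compounds named here.

In a functional assay on HeLa cells (Homo sapiens) for antiproliferative activity, read by MTT assay, with a stated time of 72 h (a lower number here means a stronger inhibitor, a higher number a weaker inhibitor), compound 1 `O=C1OCC=C1CSC(=S)NC1CC1` gives 24100 nM, and compound 2 `CC(C)N(C(=S)SCC1=CC(=O)OC1)C(C)C` gives 28500 nM; the two numbers sit within the usual scatter of each other, so neither can be set above the other. Compound 3 `O=C1OCC=C1CSC(=S)N1CCCC1` has not been measured; it differs from compound 1 by pyrrolidin-1-yl in place of cyclopropylamino on a thiocarbonyl carbon. With compound 2 already showing a similar number for another amine at the same carbon, no step beyond the scatter is expected from compound 1 to compound 3 a 1.1-fold lower number from compound 1 to compound 3 (0.04 log units; within the scatter). Compound 3 is therefore estimated at 22000 nM, between 8000 nM and 60000 nM.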

Compound 3, half-maximal inhibitory concentration: 2630 nM
Compound 3: the middle estimate sits 8.4-fold (0.92 log units) above what was measured, and the stated range ends above it.
By their numbers in this assay, from the lowest: compound 3; then compounds 1 and 2 (each within the scatter of the next).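

In this assay, the substituent on the thiocarbonyl carbon turns out to matter, which compounds 1 and 2 alone gave no sign of: pyrrolidin-1-yl in place of cyclopropylamino gives a 9.2-fold lower number from compound 1 to compound 3 (0.96 log units; beyond the scatter) and is a step beyond the scatter. This single change alters both the ring and the count of hydrogen-bond donors, so the step cannot be assigned to either one. Nothing shown explains the gain. As far as these compounds go, whether piperidin-1-yl or morpholin-4-yl on the same carbon would keep this level remains open, as does whether an azetidine ring would.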